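Swapping isopropyl for iodo in a cytotoxicity series

The source may report more compounds than this note shows. Statements on the series, on what has been measured and on what is new or still open speak of the compounds shown alone.

Two compounds sharing a core were tested in an ADME assay on HT-29 cells (Homo sapiens) for cytotoxicity, read by MTT assay, with a stated time of 72 h; on this read-out higher numbers stand for weaker inhibition and lower numbers for stronger inhibition. Compound 1 `C=CC(=O)Nc1cc(Nc2ncc3ncn(-c4ccc(I)cc4)c3n2)c(OC)cc1N(C)CCN(C)C` gives 9520 nM. Compound 2 `C=CC(=O)Nc1cc(Nc2ncc3ncn(-c4ccc(C(C)C)cc4)c3n2)c(OC)cc1N1CCN(C)CC1` gives 7690 nM. Compound 2 has the lower of the two numbers, but its gap to compound 1 lies within the usual scatter, so the two readings cannot be told apart.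

Compound 3 `C=CC(=O)Nc1cc(Nc2ncc3ncn(-c4ccc(I)cc4)c3n2)c(OC)cc1N1CCN(C)CC1` has not yet been measured. It differs from compound 2 in one place: iodo in place of isopropyl on an aromatic carbon. Going by the values given here, no measured pair shows this change on its own; compound 1 also carries iodo, yet it differs from compound 2 elsewhere as well, so its number cannot isolate the change. Among the compounds with values here, with only two close values to go on, no step beyond the scatter is expected in this assay in either direction. Compound 3 is estimated at 8000 nM, with a range from 3500 nM to 18000 nM, a step of a 1.0-fold higher number from compound 2 to compound 3 (0.02 log units; within the scatter) that is expected to stay within the scatter.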

Compound 3, half-maximal inhibitory concentration: 20700 nM
Beside the measured number, compound 3's estimate is 2.6-fold (0.41 log units) below it; the measured number lies above the stated range.
By their numbers in this assay, from the lowest: compounds 2 and 1 (each within the scatter of the next); then compound 3.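

In this assay, the change from 4-isopropylphenyl to 4-iodophenyl, taken on its own, gives a 2.7-fold higher number from compound 2 to compound 3 (0.43 log units; beyond the scatter) and so shows that the group at this position can shift the reading, if only modestly. With 4-iodophenyl held fixed, 4-methylpiperazin-1-yl in place of (2-(dimethylamino)ethyl)(methyl)amino gives a 2.2-fold higher number from compound 1 to compound 3 (0.34 log units; beyond the scatter) as a second modest step, so the other substituent counts as well; neither effect could be separated using compounds 1 and 2 alone. Nothing here gives a reason for either step.

Going by these compounds, it remains open whether the iodo step would keep its size with (2-(dimethylamino)ethyl)(methyl)amino in place of 4-methylpiperazin-1-yl. On these data alone, how a chloro group, an amine or a carboxylic acid would read at this position on the ring also remains open.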